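From butyl to 4-fluorophenyl on an amide nitrogen

A few compounds are considered here, and "the series" means these few. Any claim that something is new, unique, unknown or untested is made for them only; others in the source may bear on it.

Measured so far in a functional assay on MOLT-3 cells (Homo sapiens) for antiproliferative activity; on this read-out higher numbers stand for weaker inhibition and lower numbers for stronger inhibition:
Compound 1 `CCCCNC(=O)c1cccc(NC(=O)C(C)Br)c1` reads > 10000 nM
Compound 2 `COc1cc(NC(=O)c2cc(NC(=O)C(C)Br)ccc2O)cc(OC)c1OC` reads 1080 nM

Compound 1 sits at the limit of > 10000 nM in this assay, at which 1 of the 2 values shown sits, and this is a limit, not a number. Within the data shown here, compound 2 reads 1080 nM and is the only measured compound with an actual number.

The next compound to be measured is compound 3 `CC(Br)C(=O)Nc1cccc(C(=O)Nc2ccc(F)cc2)c1` in which 4-fluorophenyl takes the place of butyl on an amide-type nitrogen (4-fluorophenyl in place of butyl on an amide-type nitrogen) while the rest of compound 1 is kept. Among the measured compounds shown here, no measured step shows this change, so any expectation here is loose. For the measured compounds named here, it leans on compound 2 (1080 nM) as the one sign that a compound in this small set can give a number in this assay at all. A shift toward stronger inhibition is expected, beyond the usual scatter, with an estimated size of an at least 4.0-fold lower number from compound 1 to compound 3 (0.60 log units; beyond the scatter) counted from a starting point that is only a limit. Compound 3 could still report only a limit. The expected value for compound 3 is 2500 nM with an estimated range of 700 nM to 9000 nM in this assay once measured.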

Compound 3, half-maximal inhibitory concentration: 2000 nM
The estimate for compound 3 lay 1.3-fold (0.10 log units) above the measured number; the range from low to high includes it.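

Among these compounds, compound 3 gives the first one-place comparison in this assay, and replacing butyl with 4-fluorophenyl on an amide-type nitrogen produces an at least 5.0-fold lower number from compound 1 to compound 3 (0.69 log units; beyond the scatter). This shows that the group at this position can move the read-out: with the rest of compound 1 kept, 4-fluorophenyl gives an actual number where butyl gives only a limit. The full size of the step cannot be read, because compound 1 is held only at a limit, so the step gives a minimum and not a measured difference: the limit of > 10000 nM in this assay, at which 1 of the 3 values shown sits.

What the compounds shown leave open is whether the step follows the six-membered aromatic ring or the fluorine it carries, a question that a plain phenyl group at the same nitrogen would help to separate. They also leave open how other groups at this nitrogen, such as benzyl, cyclohexyl or 4-methoxyphenyl, would read in this assay, and whether a longer chain would differ from butyl.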